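Chloro for Methoxy on the Benzyl Arm

A few compounds are considered here, and "the series" means these few. Any claim that something is new, unique, unknown or untested is made for them only; others in the source may bear on it.

Compound 1 `O=C(O)c1ccccc1-c1ccc(CCc2ncc(CCC3CCCCC3)[nH]2)cc1`: 642 nM
Compound 2 `N#Cc1ccc(Cc2cnc(CCc3ccc(-c4ccccc4C(=O)O)cc3)[nH]2)cc1`: 5890 nM
Compound 3 `COc1ccc(Cc2cnc(CCc3ccc(-c4ccccc4C(=O)O)cc3)[nH]2)cc1`: 5360 nM

In an in vitro functional assay on cells for agonist activity at Bombesin receptor subtype-3 (Homo sapiens), read by luminescence and calcium flux (on this read-out higher numbers stand for an effect only at larger amounts of compound and lower numbers for an effect already at smaller amounts), compound 3 gives the second highest number of the three, within the scatter of compound 2 and well above compound 1, which sits an 8.3-fold higher number from compound 1 to compound 3 (0.92 log units; beyond the scatter). Compound 4 `O=C(O)c1ccccc1-c1ccc(CCc2ncc(Cc3ccc(Cl)cc3)[nH]2)cc1` differs from compound 3 by chloro in place of methoxy on an aromatic carbon. For the measured compounds named here, the only measured step that bears on this position is a 1.1-fold lower number from compound 2 to compound 3 (0.04 log units; within the scatter), where one group on the same aromatic carbon was exchanged for another without a change beyond the scatter. On that basis the step of a 1.2-fold lower number from compound 3 to compound 4 (0.08 log units; within the scatter) is expected to stay within the scatter. Compound 4 is therefore estimated at 4500 nM, with a range from 1800 nM to 11000 nM.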

Compound 4, half-maximal effective concentration: 2290 nM
For compound 4 the middle estimate is 2.0-fold (0.29 log units) above the measured one; measured number inside the range.
By their numbers in this assay, from the lowest: compound 1; then compound 4; then compounds 3 and 2 (each within the scatter of the next).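

Unlike the exchange of cyano for methoxy, chloro on this aromatic carbon moves the number beyond the scatter in this assay, with a 2.3-fold lower number from compound 3 to compound 4 (0.37 log units; beyond the scatter) and a 2.6-fold lower number from compound 2 to compound 4 (0.41 log units; beyond the scatter), so the group here does matter. The 4-chlorophenyl arm still does not reach the cyclohexylmethyl arm, with a 3.6-fold higher number from compound 1 to compound 4 (0.55 log units; beyond the scatter). Nothing available explains the shift from methoxy or cyano to chloro.

On these data alone, whether bromo or an amine on the same aromatic carbon would follow chloro remains open. So does what a longer chain between the core and this ring would do.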